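This account rests on a few compounds, and the source may have more. Where it says the series, first, only, none or still open, it means among the compounds named here.

Measured compounds:
- compound 1, `N=C(N)c1ccc(-c2ccc(-c3ccc(Cl)cc3)s2)s1`: 2480 nM
- compound 2, `COc1cc(OC)cc(-c2ccc(-c3ccc(C(=N)N)o3)o2)c1`: 3750 nM
- compound 3, `N=C(N)c1ccc(-c2ccc(-c3ccc4ccccc4c3)s2)s1`: 2270 nM

In a functional assay on OVCAR-8 cells (Homo sapiens) for inhibition, read by sulforhodamine B assay, with a stated time of 48 h (a higher number here means a weaker inhibitor of growth, a lower number a stronger inhibitor of growth), compound 1 gives 2480 nM. Of the three numbers it stands second highest, but its gap to compound 3, the nearest, and to compound 2, the furthest, both fall within the usual scatter of repeated measurements, so the three compounds are not separated by this assay; no word of order between them is warranted.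

The unmeasured compound 4, `N=C(N)c1ccc(-c2ccc(-c3ccc(F)cc3)s2)s1`, is reached from compound 1 by one change: fluoro in place of chloro on an aromatic carbon. Among the measured compounds shown here, no step between two measured compounds matches this change, so the expectation rests on the small spread seen across compounds 1, 2 and 3 and on the size of the change itself, a single halogen atom for another at the same position.

The step in this assay from compound 1 to compound 4 is expected to be small, a 1.1-fold higher number from compound 1 to compound 4 (0.05 log units; within the scatter), with no confident direction and most likely none beyond the scatter. Compound 4 is therefore estimated at 2800 nM, within a range from 1400 nM to 5600 nM.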

Compound 4, concentration for 50% growth inhibition: 2230 nM
Beside the measured number, compound 4's estimate is 1.3-fold (0.10 log units) above it; low and high end bracket the measured number.
By their numbers in this assay, from the lowest: compounds 4, 3, 1 and 2 (each within the scatter of the next).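

Among the compounds shown here, compound 1 and compound 4 form the first pair that differs in one place only, so the effect of a single substituent in this assay can now be read directly. Fluoro in place of chloro on an aromatic carbon of the six-membered aromatic ring, para to a large group, gives a 1.1-fold lower number from compound 1 to compound 4 (0.05 log units; within the scatter), so this assay does not separate these two halogens at this position. Compounds 1, 2 and 3 could not show this, as they differ from one another in more than one place, and their close numbers said nothing about any single position. No measurement at hand bears on why the two halogens read alike.

For the compounds shown here, still open is whether a group of another kind at this same position, such as an amine, a carboxylic acid or a nitrile, would give a step beyond the scatter, since the only pair available exchanges one halogen for another. Going by these compounds alone, also open is whether the same exchange of chloro for fluoro would read alike on a different core, as the single pair here cannot speak for any other.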